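The source may hold more compounds than are shown below. What is called first, only, known or untested is meant among the compounds shown, and "the series" means these compounds.

Going by the values given here, in a functional assay on K562 cells (Homo sapiens), read by MTT assay, with a stated time of 72 h (on this read-out higher numbers stand for weaker inhibition and lower numbers for stronger inhibition), compound 3 `CN(C)c1ncnc2c1c(-c1ccoc1)cn2[C@@H]1O[C@H](CO)[C@@H](O)[C@H]1O` gives 14900 nM, the only actual number so far. Compound 1 `CSc1ncnc2c1c(-c1ccsc1)cn2[C@@H]1O[C@H](CO)[C@@H](O)[C@H]1O`, which carries thiophen-3-yl, stands at a limit of the assay, > 20000 nM. Compound 2 `CNc1ncnc2c1c(-c1ccsc1)cn2[C@@H]1O[C@H](CO)[C@@H](O)[C@H]1O`, also with thiophen-3-yl, stands at a limit too, > 20000 nM. The ceiling in play is therefore (the limit of > 20000 nM in this assay, at which 2 of the 3 values shown sit).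

Next to be read is compound 4 `CN(C)c1ncnc2c1c(-c1ccsc1)cn2[C@@H]1O[C@H](CO)[C@@H](O)[C@H]1O`, with thiophen-3-yl in place of furan-3-yl on an aromatic carbon of the five-membered aromatic ring of the shared core: thiophen-3-yl in place of furan-3-yl on an aromatic carbon.

Among the compounds with values here, the only measured step is a step that the two limits leave unreadable from compound 1 to compound 2. It places methylamino in place of methylsulfanyl, elsewhere on the core, and gives no size to carry over. No direct furan-3-yl to thiophen-3-yl comparison has been measured. The expectation in this assay is therefore no step beyond the scatter, with only a slight lean towards weaker inhibition, since compound 2 with thiophen-3-yl stands at its limit of > 20000 nM. The expected step is a 1.1-fold higher number from compound 3 to compound 4 (0.03 log units; within the scatter). For compound 4 the estimate is 16000 nM, with an expected range from 7000 nM to 35000 nM.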

Compound 4, half-maximal inhibitory concentration: > 20000 nM
Compound 4: a limit, no number (the forecaster's own chance of this, stated with the estimate: 40%); at least 1.2-fold (0.09 log units) between middle value and limit.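

In this assay, going by these compounds alone, the change of furan-3-yl to thiophen-3-yl on an aromatic carbon of the five-membered aromatic ring gives the first comparison at this position: an at least 1.3-fold higher number from compound 3 to compound 4 (0.12 log units; that floor lies within the scatter). Only a floor is known for this step, and the printed floor does not by itself separate the two groups, so the pair may differ by little or by much more. The steps among compound 1, compound 2 and compound 4 cannot be read, so methylsulfanyl, methylamino and dimethylamino cannot be ranked on the thiophen-3-yl compounds, and the ceiling now covers most of the series: the limit of > 20000 nM in this assay, at which 3 of the 4 values shown sit.

Within the data shown here, the size of the furan-3-yl to thiophen-3-yl step remains open, as does whether furan-3-yl would give a number alongside methylamino or methylsulfanyl, with compound 3 still the only compound with an actual value. Also open, going by these compounds, is how a phenyl group or a carboxylic acid on the same aromatic carbon would read in this assay, and whether either would bring a compound clearly below the ceiling.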